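A few compounds are considered here, and "the series" means these few. Any claim that something is new, unique, unknown or untested is made for them only; others in the source may bear on it.

Of the compounds shown here, two have so far been tested in an ADME assay on Vero cells (Chlorocebus sabaeus) for cytotoxicity, read by MTT assay, with a stated time of 72 h; on this read-out lower numbers stand for higher toxicity in this test and higher numbers for lower toxicity in this test. Compound 1 `NS(=O)(=O)c1ccc(N2N=C(c3ccc(Cl)cc3Cl)CC2c2cn(-c3ccccc3)nc2-c2ccccc2)cc1` gives only a limit of the assay, > 437000 nM. Among the compounds with values here, compound 2 `NS(=O)(=O)c1ccc(N2N=C(c3ccc(Br)cc3)CC2c2cn(-c3ccccc3)nc2-c2ccc(F)cc2)cc1` gives 49400 nM, the only full number so far. The other result is the limit of > 437000 nM in this assay, at which 1 of the 2 values shown sits. Compound 3 `NS(=O)(=O)c1ccc(N2N=C(c3ccc(O)cc3)CC2c2cn(-c3ccccc3)nc2-c2ccc(F)cc2)cc1` has not been measured yet; it differs from compound 2 by hydroxy in place of bromo on an aromatic carbon. Within the data shown here, no measured pair shows this kind of change, so only a modest move toward a higher number, meaning lower toxicity, is expected, as the step of a 1.8-fold higher number from compound 2 to compound 3 (0.26 log units; within the scatter). Compound 3 is therefore estimated at 90000 nM, within a range from 35000 nM to 300000 nM.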

Compound 3, half-maximal cytotoxic concentration: 32000 nM
The estimate for compound 3 lay 2.8-fold (0.45 log units) above the measured number; measured number below the stated range.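

At this place, para to a large group, hydroxy brings a hydrogen-bond donor and acceptor that bromo lacks, yet in this assay the change gives a 1.5-fold lower number from compound 2 to compound 3 (0.19 log units; within the scatter) and no more than that. On this one pair, then, 4-bromophenyl and 4-hydroxyphenyl cannot be told apart in this test. Within the data shown here, nothing measured so far offers a reason for this result. From the compounds shown here alone, whether an amine or a carboxylic acid on the same aromatic carbon would also stay within the scatter remains open. A single pair also cannot show whether this change behaves the same way on other compounds.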